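A few compounds are considered here, and "the series" means these few. Any claim that something is new, unique, unknown or untested is made for them only; others in the source may bear on it.

Measured in a functional assay on U-251 cells (Homo sapiens) for inhibition, read by sulforhodamine B assay, with a stated time of 48 h; on this read-out lower numbers stand for stronger inhibition of growth and higher numbers for weaker inhibition of growth: compound 1 `CC1=CC[C@H](C(C)(C)NC(=S)NN)CC1` gives 200 nM; compound 2 `CC1=CC[C@H](C(C)(C)NC(=S)N/N=C/c2cccc(Cl)c2)CC1` gives 7900 nM; compound 3 `CC1=CC[C@H](C(C)(C)NC(=S)N/N=C/c2ccc(Cl)cc2)CC1` gives 69500 nM.

Compound 1 holds the lowest number of the three, with the others standing well beyond the scatter above it. The unmeasured compound 4 `CC1=CC[C@H](C(C)(C)NC(=S)N/N=C/c2ccco2)CC1` differs from compound 1 by a group of 7 heavy atoms (5 carbon, 1 nitrogen, 1 oxygen; one five-membered aromatic ring with 1 hetero atom) in place of one nitrogen atom, on an amide-type nitrogen. Among the measured compounds shown here, no measured step covers this change directly; the single recorded step, an 8.8-fold higher number from compound 2 to compound 3 (0.94 log units; beyond the scatter), concerns only the substitution on a ring that is already present. Compounds 2 and 3, which both carry an aromatic ring at this position where compound 1 has only nitrogen, return far higher numbers than compound 1, so a large rise in this assay is expected, a 75-fold higher number from compound 1 to compound 4 (1.88 log units; beyond the scatter). Compound 4 is estimated at 15000 nM, within a range from 3000 nM to 80000 nM.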

Compound 4, concentration for 50% growth inhibition: 9700 nM
Estimate against measurement, compound 4: 1.5-fold (0.19 log units) above, and the stated range covers the measured number.
By their numbers in this assay, from the lowest: compound 1; then compounds 2 and 4 (each within the scatter of the next); then compound 3.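

Compound 4 shows that the large rise is not tied to a chlorophenyl ring: with furan-2-yl on the carbon with a double bond to nitrogen, this assay gives a 49-fold higher number from compound 1 to compound 4 (1.69 log units; beyond the scatter) as the amino group leaves. The ring still matters, with a 7.2-fold lower number from compound 3 to compound 4 (0.86 log units; beyond the scatter) against 4-chlorophenyl, while a 1.2-fold higher number from compound 2 to compound 4 (0.09 log units; within the scatter) leaves furan-2-yl and 3-chlorophenyl inside the scatter. Nothing given here accounts for these differences. Still open, going by these compounds, is whether a pyridine ring or a plain alkyl chain on that carbon would bring the number back towards that of compound 1.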